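Cyano in place of nitro on a shared core

A few compounds are considered here, and "the series" means these few. Any claim that something is new, unique, unknown or untested is made for them only; others in the source may bear on it.

compound 1, `CC(=O)c1ccc(Nc2ccnc(SCC(=O)c3ccc(Br)cc3)n2)cc1`: 19%
compound 2, `CCOC(=O)c1ccc(Nc2ccnc(SCC(=O)c3ccc([N+](=O)[O-])cc3)n2)cc1`: 28%

Both were measured in a functional assay on BT-549 cells (Homo sapiens) for inhibition, read by sulforhodamine B assay, with a stated time of 48 h, tested at 10 uM; on this read-out higher numbers stand for more inhibition of growth at the one concentration tested and lower numbers for less inhibition of growth. Compound 2 shows the higher of the two numbers, but its gap to compound 1 lies within the scatter, so the two cannot be ranked. Compound 3, `CCOC(=O)c1ccc(Nc2ccnc(SCC(=O)c3ccc(C#N)cc3)n2)cc1`, is not yet measured; it differs from compound 2 by cyano in place of nitro on an aromatic carbon. Among the measured compounds shown here, no measured pair shows this change, so no step can guide the guess. In this assay the expected step of a number 3 percentage points lower from compound 2 to compound 3 (within the scatter) is small, not beyond the scatter. Compound 3 is estimated at 25%, between 5% and 45%.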

Compound 3, percent growth inhibition at one concentration: 50%
Compound 3: the middle estimate sits 25 percentage points below what was measured; measured number above the stated range.
By their numbers in this assay, from the lowest: compounds 1 and 2 (each within the scatter of the next); then compound 3.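

In this assay, cyano in place of nitro gives a number 22 percentage points higher from compound 2 to compound 3 (beyond the scatter), and this single change clears the scatter. The group at this place, para to a large group, therefore matters to the read-out, even though the rest of the molecule stays the same. No measurement shown here explains why the swap has this effect.

The compounds shown leave open how an amine or a carboxylic acid would read at the same place. They also leave open whether other groups there would give a higher or lower number than cyano does.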